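A few compounds are considered here, and "the series" means these few. Any claim that something is new, unique, unknown or untested is made for them only; others in the source may bear on it.

In an ADME assay on L6 cells (Rattus norvegicus) for cytotoxicity, read by resazurin assay, with a stated time of 72 h (a higher number here means a weaker inhibitor, a lower number a stronger inhibitor), compound 1 `O=[N+]([O-])c1ncn(CCCNS(=O)(=O)c2cc(Cl)c(Cl)s2)n1` gives 101000 nM as a measured number. Compound 2 `O=C(NCCCn1cnc([N+](=O)[O-])n1)c1ccsc1` gives > 356000 nM and this is a limit of the assay, not a number. Compound 2 therefore stands at the limit of > 356000 nM in this assay, at which 1 of the 2 values shown sits, on the data so far. Compound 3 `Cc1ccoc1C(=O)NCCCn1cnc([N+](=O)[O-])n1` has 3-methylfuran-2-yl in place of thiophen-3-yl on a carbonyl carbon and otherwise matches compound 2. Among the compounds with values here, no measured step guides this change, so only a modest move towards a lower number is expected, estimated as an at least 1.4-fold lower number from compound 2 to compound 3 (0.15 log units; that floor lies within the scatter) in this assay for now. Compound 3 is expected to read about 250000 nM with an estimated range from 90000 nM to 360000 nM in this measurement.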

Compound 3, half-maximal inhibitory concentration: > 358000 nM
Compound 3 ended at the assay's limit; the forecaster's own chance of this, stated with the estimate: 55%; middle value at least 1.4-fold (0.15 log units) away from the limit.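

Compound 2 and compound 3 both read as limits, not numbers, and the step between them cannot be read. On these data alone, whether 3-methylfuran-2-yl in place of thiophen-3-yl on a carbonyl carbon changes the true value remains open.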